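Swapping the Halogenated Phenyl for a Methylbenzyl

A few compounds are considered here, and "the series" means these few. Any claim that something is new, unique, unknown or untested is made for them only; others in the source may bear on it.

Measured compounds in an assay on CHO cells for displacement of a labelled ligand from adenosine receptor A3 (Homo sapiens), read by scintillation counting, with a stated time of 45 min, tested at 1 uM, in the presence of a further agent that is not named here; on this read-out higher numbers stand for more inhibition at the one concentration tested (going by the name of the read-out) and lower numbers for less inhibition:
Compound 1 `CCCn1c(=O)[nH]c2nc(-c3ccc(S(=O)(=O)N4CCN(c5cccc(Br)c5)CC4)cc3)[nH]c2c1=O` gives 27%.
Compound 2 `CCCn1c(=O)[nH]c2nc(-c3ccc(S(=O)(=O)N4CCN(c5ccc(Br)cc5)CC4)cc3)[nH]c2c1=O` gives 29%.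
Compound 3 `CCCn1c(=O)[nH]c2nc(-c3ccc(S(=O)(=O)N4CCN(c5ccc(I)cc5)CC4)cc3)[nH]c2c1=O` gives 36%.

Among these three, compound 1 carries the lowest number, yet its neighbours sit close: the step of a number 2 percentage points higher from compound 1 to compound 2 (within the scatter) and the step of a number 9 percentage points higher from compound 1 to compound 3 (within the scatter) both fall within the scatter of repeated measurements, so the three compounds cannot be told apart on this read-out. The remaining comparison, a number 7 percentage points higher from compound 2 to compound 3 (within the scatter), is likewise within the scatter.

Compound 4 `CCCn1c(=O)[nH]c2nc(-c3ccc(S(=O)(=O)N4CCN(Cc5cccc(C)c5)CC4)cc3)[nH]c2c1=O` has not yet been measured. It differs from compound 1 in one place: 3-methylbenzyl in place of 3-bromophenyl on an amine nitrogen in a ring. Going by the values given here, none of the measured steps tests this kind of change; they only exchange one halogen-bearing phenyl for another, and each left the number essentially where it was. The rest of the molecule is untouched. Among the compounds with values here, with no measured precedent for a benzyl group on that nitrogen, the soundest expectation is that compound 4 stays near compound 1, with a step of a number 1 percentage points higher from compound 1 to compound 4 (within the scatter) that is expected to remain within the scatter, though the missing precedent calls for a wide range. Compound 4 is therefore estimated at 28% in this assay, expected to lie between 5% and 52%.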

Compound 4, a percentage reported as inhibition, at one concentration (the size of the read-out at that concentration, not a potency): 17%
The estimate for compound 4 lay 11 percentage points above the measured number; measured number inside the range.
By their numbers in this assay, from the lowest: compounds 4, 1, 2 and 3 (each within the scatter of the next, the first and the last beyond it).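

Placing 3-methylbenzyl on the amine nitrogen is the first change at this position whose effect in this assay reaches beyond the scatter, with a number 19 percentage points lower from compound 3 to compound 4 (beyond the scatter) and a number 12 percentage points lower from compound 2 to compound 4 (beyond the scatter) as the two steps that show it, while a number 10 percentage points lower from compound 1 to compound 4 (within the scatter) remains the one step of the three that cannot be told from repeat variation. Going by these compounds alone, the exchanges of one halogen-bearing phenyl for another gave no sign that the number responds to what this nitrogen carries, so this is the first hint that it can, though the response is small and depends on which halogen-bearing compound serves as the comparison. No available data explain the shift, and with a benzyl and a methyl entering as a halogen-bearing phenyl leaves, it cannot be assigned to any one of these parts.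

The compounds shown leave open whether the benzyl or its methyl matters more, a question that a plain benzyl and a 3-bromobenzyl on the same nitrogen could separate. They also leave open how a longer chain such as phenethyl, or a carboxylic acid on the aromatic ring, would change the number in this assay.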